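Compound 4: one trifluoromethyl anchor for an estimate

A few compounds are considered here, and "the series" means these few. Any claim that something is new, unique, unknown or untested is made for them only; others in the source may bear on it.

Compound 1 `COc1ccc(-c2c(Nc3cccc(C(F)(F)F)c3)c3ccccc3oc2=O)cc1` gives 55700 nM
Compound 2 `COc1ccc(-c2c(Nc3ccc(F)cc3)c3ccc(OC)cc3oc2=O)cc1` gives "not determined" (no result reported)
Compound 3 `COc1ccc(-c2c(Nc3ccc(NC(C)=O)cc3)c3ccc(OC)cc3oc2=O)cc1` gives "not determined" (no result reported)

All of these entries come from a functional assay on HCT-116 cells (Homo sapiens) for antiproliferative activity, read by MTT assay, with a stated time of 48 h; a lower number here means a stronger inhibitor, a higher number a weaker inhibitor. Only compound 1 has a number there, so compound 3 cannot be ranked against anything and simply stands without a position, as compound 2 does.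

The next compound, compound 4 `COc1ccc(-c2c(Nc3cccc(C(F)(F)F)c3)c3ccc(OC)cc3oc2=O)cc1`, has not been measured yet. The change 3-(trifluoromethyl)phenyl in place of 4-acetamidophenyl on a nitrogen on an aromatic ring puts 3-(trifluoromethyl)phenyl in place of 4-acetamidophenyl on a nitrogen on an aromatic ring.

Within the data shown here, no pair of measured compounds shows how large such a change can be, and the missing number for compound 3 leaves no starting point for a step. The best guide is compound 1, which carries the same 3-(trifluoromethyl)phenyl group and gives 55700 nM. In this assay, compound 4 is therefore expected to land close to that value, with no gap beyond the usual scatter in either direction.

For compound 4 the estimated value is 45000 nM, with an expected range from 15000 nM to 120000 nM.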

Compound 4, half-maximal inhibitory concentration: 41200 nM
Compound 4: the middle estimate sits 1.1-fold (0.04 log units) above what was measured; the measured number falls inside the stated range.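

Among these compounds, the first step that can be read in this assay is a 1.4-fold lower number from compound 1 to compound 4 (0.13 log units; within the scatter) and comes from methoxy in place of hydrogen on an aromatic carbon of the core. With 3-(trifluoromethyl)phenyl on the nitrogen, then, adding this methoxy leaves the result within the usual scatter of the assay. Compound 3 has no number, so the exchange of 4-acetamidophenyl for 3-(trifluoromethyl)phenyl cannot be read, and no measurement offered here explains the result.

The compounds shown leave open whether a hydroxyl group or a longer ether such as ethoxy on that same carbon would give a clear step. They also leave open how an amine or a carboxylic acid on the phenyl ring attached to the nitrogen would compare with 3-(trifluoromethyl)phenyl.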